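The source may report more compounds than this note shows. Statements on the series, on what has been measured and on what is new or still open speak of the compounds shown alone.

Of the compounds shown here, three built on one shared core have been tested in a functional assay on PC-3 cells (Homo sapiens) for antiproliferative activity, read by MTT assay, with a stated time of 48 h; a higher number here means a weaker inhibitor, a lower number a stronger inhibitor. Compound 1 `O=C(/C=C\Nc1ccc(F)cc1)c1cn(-c2ccccc2)nc1-c1ccc(Cl)cc1` reaches only the assay limit of > 50000 nM. Compound 2 `O=C(/C=C\Nc1ccc(Cl)cc1)c1cn(-c2ccccc2)nc1-c1ccc(Cl)cc1` gives 3890 nM. Compound 3 `COc1ccc(N/C=C\C(=O)c2cn(-c3ccccc3)nc2-c2ccc(Cl)cc2)cc1` gives 10700 nM, the highest of the two numbers, with compound 2 nearest. The measured steps each change one substituent on a phenyl ring: an at least 12-fold lower number from compound 1 to compound 2 (1.10 log units; beyond the scatter), an at least 4.6-fold lower number from compound 1 to compound 3 (0.66 log units; beyond the scatter) and a 2.8-fold higher number from compound 2 to compound 3 (0.44 log units; beyond the scatter). Compound 4 `COc1ccc(N/C=C\C(=O)c2cn(-c3ccccc3)nc2-c2ccc(OC)cc2)cc1` differs from compound 3 in a single place: methoxy in place of chloro on an aromatic carbon. The step of a 2.8-fold higher number from compound 2 to compound 3 (0.44 log units; beyond the scatter) is the same exchange, though on the other phenyl ring, and it raised the number modestly; a similar modest rise toward a weaker inhibitor is therefore expected, a 2.3-fold higher number from compound 3 to compound 4 (0.37 log units; beyond the scatter). Compound 4 is estimated at 25000 nM, plausibly between 8000 nM and 80000 nM, and it may reach the assay limit.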

Compound 4, half-maximal inhibitory concentration: 13400 nM
Estimate against measurement, compound 4: 1.9-fold (0.27 log units) above; measured number inside the range.
By their numbers in this assay, from the lowest: compound 2; then compounds 3 and 4 (each within the scatter of the next). At a limit, above all of these: compound 1.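

In this assay, exchanging 4-chlorophenyl for 4-methoxyphenyl gives a 1.3-fold higher number from compound 3 to compound 4 (0.10 log units; within the scatter), so at this position the exchange leaves no readable change. The same exchange on the other phenyl ring gave a 2.8-fold higher number from compound 2 to compound 3 (0.44 log units; beyond the scatter), so in these two pairs the outcome depends on which ring carries it. Nothing measured here bears on why the two rings differ.

Still open, on these data alone, is how this position would respond to an amine or a carboxylic acid. Also open, as far as these compounds go, is whether the exchange would read the same starting from compound 2.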